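The compounds below may be only part of what the source reports. "The series", "measured", "known", "first", "only" and "open" are said of these compounds alone.

Measured so far:
compound 1, `CC(C)(C)OC(=O)N1CCC(Oc2ncnc3c2CCN3c2ccc(S(C)(=O)=O)cc2F)CC1`: 139%
compound 2, `CCS(=O)(=O)N1CCC(Oc2ncnc3c2CCN3c2ccc(S(C)(=O)=O)cc2F)CC1`: 51%

Among the compounds with values here, in a functional assay on CHO-K1 cells with Glucose-dependent insulinotropic receptor (Homo sapiens) as the target, read by a luciferase reporter, with a stated time of 5 h (a lower number here means a smaller maximal response, a higher number a larger maximal response), compound 2 holds the lowest of the two numbers; the one measured step, a number 88 percentage points lower from compound 1 to compound 2 (beyond the scatter), is large and beyond the scatter. Compound 3, `CN(C)S(=O)(=O)N1CCC(Oc2ncnc3c2CCN3c2ccc(S(C)(=O)=O)cc2F)CC1`, is not yet measured. It differs from compound 2 by dimethylamino in place of ethyl on a sulfonyl sulfur. The step from compound 1 to compound 2 bears on this only loosely: that step replaced a carbamate with a sulfonyl and moved the read-out far downward, whereas the step to compound 3 keeps the sulfonyl and alters only the group on its sulfur. Within the data shown here, no measured pair shows the effect of such a change on the sulfur substituent. A step within or only slightly beyond the scatter is therefore expected, with the direction uncertain. For compound 3 the estimate is 55% (range 30% to 90%), which means an expected step of a number 4 percentage points higher from compound 2 to compound 3 (within the scatter).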

Compound 3, largest response reached (reported as percent of maximum), in percent of the reference or control that the assay uses: 68%
Compound 3: the middle estimate sits 13 percentage points below what was measured; the range from low to high includes it.
By their numbers in this assay, from the lowest: compound 2; then compound 3; then compound 1.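

In this assay, within the data shown here, the group on the sulfonyl sulfur proves able to shift the read-out: dimethylamino in place of ethyl gives a number 17 percentage points higher from compound 2 to compound 3 (beyond the scatter) as a modest step, which is the first measured change at this sulfur. The sulfonyl compounds still stay well under the carbamate, with a number 71 percentage points lower from compound 1 to compound 3 (beyond the scatter) as a large step, so dimethylsulfamoyl regains only part of what was lost with ethylsulfonyl. Nothing measured here bears on the origin of either step.

Going by these compounds, it remains open whether a cyclic amine such as pyrrolidine or a longer chain on the sulfonyl sulfur would move the maximal response further. Also open, on these data alone, is whether, against compound 1 with 139% as the mark, any sulfonyl group on the amine nitrogen in the ring comes close.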